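The source may report more compounds than this note shows. Statements on the series, on what has been measured and on what is new or still open speak of the compounds shown alone.

In a functional assay (aorta) with Oryctolagus cuniculus as the target (a higher number here means weaker binding, a lower number tighter binding), compound 1 (`CCCc1nc2c(C)ccnc2n1Cc1ccc(-c2ccccc2C(=O)O)cc1`) gives 3.16 nM; 3.16 nM (2 entries), compound 2 (`Cc1ccnc2c1nc(C)n2Cc1ccc(-c2ccccc2C(=O)O)cc1`) gives 50.1 nM and compound 3 (`CCCCc1nc2c(C)ccnc2n1Cc1ccc(-c2ccccc2C(=O)O)cc1`) gives 7.94 nM. Compound 3 therefore sits between the other two, with a lower number than compound 2 and a higher one than compound 1.

Compound 4 (`COCc1nc2c(C)ccnc2n1Cc1ccc(-c2ccccc2C(=O)O)cc1`) has methoxy in place of propyl on a saturated chain carbon bound to an aromatic carbon. Cut one bond further out, the same change reads butyl to methoxymethyl.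

Among the measured compounds shown here, one measured step bears on this place: a 6.3-fold lower number from compound 2 to compound 3 (0.80 log units; beyond the scatter), with propyl in place of hydrogen. For the measured compounds named here, that step shows that the number in this assay responds to changes at this place, but no measured compound has an oxygen in this chain, so the direction of the new step is uncertain. A modest move towards a higher number is expected, smaller than the step to compound 3, and it is estimated as a 1.9-fold higher number from compound 3 to compound 4 (0.28 log units; within the scatter). The expected value for compound 4 is 15 nM, with an estimated range from 5 nM to 45 nM.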

Compound 4, dissociation constant: 79.4 nM
The estimate for compound 4 lay 5.3-fold (0.72 log units) below the measured number, outside the stated range (above it).
By their numbers in this assay, from the lowest: compound 3; then compounds 2 and 4 (each within the scatter of the next).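

In this assay, the swap from propyl to methoxy at this saturated chain carbon is a large one, with a 10-fold higher number from compound 3 to compound 4 (1.00 log units; beyond the scatter) beyond the scatter. The benefit of propyl over hydrogen does not carry over to methoxy: a 1.6-fold higher number from compound 2 to compound 4 (0.20 log units; within the scatter) lies within the scatter, so the two cannot be told apart in this assay. Nothing available explains why this oxygen-containing chain behaves so differently from the all-carbon one.

This single change alters both the presence of oxygen and the number of heavy atoms, so the compounds shown cannot separate the two. Going by these compounds, how an ethoxymethyl chain, which has oxygen and the same heavy-atom count as butyl, or an amine such as aminomethyl would behave at this place remains open.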